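The source may report more compounds than this note shows. Statements on the series, on what has been measured and on what is new or still open speak of the compounds shown alone.

Measured in a physicochemical assay for lipophilicity, at pH 7.4; on this read-out higher numbers stand for higher lipophilicity and lower numbers for lower lipophilicity:
- compound 1 `CNC(=O)c1cc(C(=O)N[C@H]2[C@@H]3COC[C@@H]32)cc2c1OC[C@H]2c1ccccc1`: 3.3
- compound 2 `CNC(=O)c1cc(C(=O)NCCC[C@H]2OC[C@H](N)CO2)cc2c1OC[C@H]2c1ccccc1`: 2.6
- compound 3 `CNC(=O)c1cc(C(=O)NC)c2c(c1)[C@H](c1ccccc1)CO2`: 3.2

Compound 3 shares the top of this small set with compound 1 and sits clear of compound 2. The steps read a number 0.10 log units lower from compound 1 to compound 3 (within the scatter) and a number 0.60 log units higher from compound 2 to compound 3 (beyond the scatter). The next change leads to compound 4 `CNC(=O)c1cc(C(=O)N[C@H]2C[C@@H]2C)cc2c1OC[C@H]2c1ccccc1`, with 2-methylcyclopropyl in place of methyl on an amide-type nitrogen. Those steps, and a number 0.70 log units lower from compound 1 to compound 2 (beyond the scatter), all change the group on that nitrogen. None of them brings in a group of carbon only that is larger than methyl, so they guide the expectation only loosely. A modest rise is expected in this assay, as the estimated step of a number 0.50 log units higher from compound 3 to compound 4 (beyond the scatter). For compound 4 the estimated value is 3.7, with an expected range of 3.3 to 4.2.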

Compound 4, distribution coefficient: 4.5
The estimate for compound 4 lay 0.80 log units below the measured number; the whole stated range lies below it.
By their numbers in this assay, from the lowest: compound 2; then compounds 3 and 1 (each within the scatter of the next); then compound 4.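

On the amide-type nitrogen, 2-methylcyclopropyl in place of methyl shifts the number in this assay far more than the earlier changes there did (a number 1.30 log units higher from compound 3 to compound 4 (beyond the scatter)). This carbon-only group also stands well clear of the groups containing oxygen (a number 1.20 log units higher from compound 1 to compound 4 (beyond the scatter); a number 1.90 log units higher from compound 2 to compound 4 (beyond the scatter)). Nothing available explains the size of these steps.

On these data alone, what remains open is how much of the step comes from the three-membered ring and how much from the added methyl. Plain cyclopropyl or an ethyl chain on the same nitrogen would help separate the two, and the other stereoisomers of 2-methylcyclopropyl remain to be compared.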